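The source may hold more compounds than are shown below. What is called first, only, known or untested is meant among the compounds shown, and "the series" means these compounds.

Three measured compounds share one core. Compound 1 `O=C(Nc1cc(C(F)(F)F)cc(C(F)(F)F)c1)C1CCc2ccccc2N1C(=O)c1ccc(Cl)cc1` gives, in a functional assay on ACHN cells (Homo sapiens) for cytotoxicity, read by sulforhodamine B assay, with a stated time of 72 h (on this read-out higher numbers stand for weaker inhibition of growth and lower numbers for stronger inhibition of growth), a value of 2570 nM, which is the second highest of the three numbers. Compound 2 `O=C(Nc1ccccc1O)C1CCc2ccccc2N1C(=O)c1ccccc1` gives 4260 nM, and this lies within the scatter of compound 1. Compound 3 `O=C(Nc1ccccc1C(F)(F)F)C1CCc2ccccc2N1C(=O)c1ccc(Cl)cc1` gives 824 nM, a lower number that stands beyond the scatter from compound 1. Compound 4 `CCCCCCCCC(=O)N1c2ccccc2CCC1C(=O)Nc1cc(C(F)(F)F)cc(C(F)(F)F)c1` has not yet been measured; it differs from compound 1 in one place: octyl in place of 4-chlorophenyl on a carbonyl carbon. For the measured compounds named here, no pair of measured compounds shows this change on its own, so no measured step guides it. The step from compound 1 to compound 4 is expected to be small, a 1.4-fold higher number from compound 1 to compound 4 (0.13 log units; within the scatter), with no clear direction beyond the scatter. Compound 4 is therefore estimated at 3500 nM, within a range from 1200 nM to 10000 nM.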

Compound 4, concentration for 50% growth inhibition: 4520 nM
Beside the measured number, compound 4's estimate is 1.3-fold (0.11 log units) below it, and the stated range covers the measured number.
By their numbers in this assay, from the lowest: compound 3; then compounds 1, 2 and 4 (each within the scatter of the next).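

On a carbonyl carbon bound to the amide-type nitrogen in a ring, octyl in place of 4-chlorophenyl gives a 1.8-fold higher number from compound 1 to compound 4 (0.25 log units; within the scatter) in this assay. With the rest of compound 1 kept, this position therefore tolerates losing the aromatic ring and the chlorine, and an open chain serves as well as the ring in this assay. Nothing measured here gives a reason for this result. Still open, going by these compounds, is whether a shorter chain such as butyl, or a chain ending in an amine or a carboxylic acid, would stay as close to compound 1. Also open, on these data alone, is whether the same change would read alike starting from compound 3.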